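Hydroxy for Sulfanyl at the End of a Long Chain

The source may report more compounds than this note shows. Statements on the series, on what has been measured and on what is new or still open speak of the compounds shown alone.

Compound 3 `Cn1cc(NC(=O)CCCCCCCCCCS)c(-c2ccccn2)n1` has been tested in a functional assay on U-87MG ATCC cells (Homo sapiens) for cytotoxicity, read by MTT assay, with a stated time of 24 h; a higher number here means a weaker inhibitor, a lower number a stronger inhibitor. In this assay compound 3 gives only a limit, > 150000 nM. Compound 2 `CCCCCCCCCCCC(=O)Nc1cn(C)nc1-c1ccccn1` differs from compound 3 by sulfanyl in place of methyl on a saturated chain carbon, ten or more bonds along the chain from a carbonyl carbon. In this assay compound 2 also gives only a limit, > 150000 nM. Compound 1 `O=C(CCCCCCCCCCO)Nc1cn(-c2ccccc2)nc1-c1ccccc1`, which carries a hydroxy at the end of its chain on a different core, gives only a limit in this assay, > 150000 nM. All three values sit at the limit of > 150000 nM in this assay, at which 3 of the 3 values shown sit, so the step that the two limits leave unreadable from compound 2 to compound 3 cannot be read.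

Compound 4 `Cn1cc(NC(=O)CCCCCCCCCCO)c(-c2ccccn2)n1` differs from compound 3 by hydroxy in place of sulfanyl on a saturated chain carbon, ten or more bonds along the chain from a carbonyl carbon. For the measured compounds named here, no measured step shows what a hydroxy in place of a sulfanyl does in this assay; the only evidence is that compound 1, bearing a hydroxy at a chain end, and compound 3, bearing a sulfanyl, both stand at the limit. Compound 4 is therefore expected to remain at the limit, with no step beyond the scatter, which for compound 4 means an expected step of a number no higher from compound 3 to compound 4 (the limit leaves the size open). The estimate for compound 4 in this assay is 150000 nM, expected to lie between 60000 nM and 400000 nM.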

Compound 4, half-maximal inhibitory concentration: > 150000 nM
Compound 4: only a limit was reported (the forecaster's own chance of this, stated with the estimate: 85%); the middle value lies on the limit itself.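

In this assay compound 4 gives only a limit, > 150000 nM. No step to compound 4 can be read from compound 2 or compound 3, and all the compounds shown stand at one value: the limit of > 150000 nM in this assay, at which 4 of the 4 values shown sit.

The compounds shown leave open whether hydroxy in place of sulfanyl at the chain end changes the result in this assay at all.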